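Replacing an Aromatic Amide Substituent with a Bicyclic One

The compounds below may be only part of what the source reports. "The series", "measured", "known", "first", "only" and "open" are said of these compounds alone.

For the measured compounds named here, compound 1 `O=C(Nc1ccccc1O)c1cccc(N2C(=O)c3ccccc3C2=O)c1` is the stronger of the two compounds measured so far in an in vitro functional assay on HEK293-A cells for antagonist activity at metabotropic glutamate receptor 5 (Rattus norvegicus), read by calcium flux; a higher number here means a weaker inhibitor, a lower number a stronger inhibitor. In this assay compound 1 gives 77 nM, while compound 2 `COc1ccccc1C(=O)Nc1cccc(NC(=O)c2cccc(C#N)c2)c1` gives 1800 nM, a gap that lies well beyond the usual scatter. Compound 3 `O=C(NC1CC2CCC1C2)c1cccc(N2C(=O)c3ccccc3C2=O)c1` keeps the shared core of compound 1 but differs at one place: a group of 7 heavy atoms (7 carbon; 2 five-membered non-aromatic rings of carbon only) in place of a group of 7 heavy atoms (6 carbon, 1 oxygen; one six-membered aromatic ring of carbon only), on an amide-type nitrogen. Going by the values given here, no measured pair shows this particular change, so its effect has to be estimated rather than read off. Since the aromatic group with its hydroxyl is exchanged for a saturated bicyclic group without any donor or acceptor, a moderate loss of inhibitory strength is expected, and the step from compound 1 to compound 3 is estimated to be a 5.2-fold higher number from compound 1 to compound 3 (0.72 log units; beyond the scatter) towards weaker inhibition. Compound 3 is therefore expected to give about 400 nM in this assay, most likely within the range from 80 nM to 2500 nM.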

Compound 3, half-maximal inhibitory concentration: > 30000 nM
Compound 3: no number, only a limit; the forecaster's own chance of this, stated with the estimate: 15%; middle value at least 75-fold (1.87 log units) away from the limit.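

In this assay, the exchange of the 2-hydroxyphenyl for the saturated bicyclic group on the amide-type nitrogen gives an at least 380-fold higher number from compound 1 to compound 3 (2.59 log units; beyond the scatter), so the group at this place can decide whether any inhibition is seen at all, even with the shared core unchanged. Compound 2 differs from compound 1 in more than one place and could not show this. The figure for compound 3 is a limit and not a number, so the step has no known upper end: the limit of > 30000 nM in this assay, at which 1 of the 3 values shown sits.

The compounds shown leave open whether the hydroxyl or the aromatic ring of the 2-hydroxyphenyl matters more, as both leave together in this single step. A plain phenyl group at this place would keep the ring without the hydroxyl, and a cyclohexyl group would test another saturated ring.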